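Solubility notes on a fused thienopyrimidine series, compound 3

The source may report more compounds than this note shows. Statements on the series, on what has been measured and on what is new or still open speak of the compounds shown alone.

Measured so far:
compound 1, `CNc1nc(OCCCN(C)C)c2sc(-c3ccc(C(F)(F)F)cc3)cc2n1`, 174 ug/mL
compound 2, `CNc1nc(N2CCC(N)CC2)c2sc(-c3ccc(C(F)(F)F)cc3)cc2n1`, 17 ug/mL

Among the compounds with values here, in a physicochemical assay for solubility, in phosphate buffer, at pH 6.5 (on this read-out higher numbers stand for higher solubility and lower numbers for lower solubility), compound 2 gives the lower of the two numbers; its nearest neighbour is compound 1, and the single step of a 10-fold lower number from compound 1 to compound 2 (1.01 log units; beyond the scatter) separates them. Compound 3, `CNc1nc(Nc2cccc(C(N)=O)c2)c2sc(-c3ccc(C(F)(F)F)cc3)cc2n1`, has not yet been measured in this assay. It differs from compound 2 by (3-carbamoylphenyl)amino in place of 4-aminopiperidin-1-yl on an aromatic carbon. Within the data shown here, no measured step covers an exchange of this kind: the step from compound 1 to compound 2 swaps one side chain for a ring-bearing amine, whereas here a saturated ring with an amino group gives way to an aromatic ring carrying a carboxamide, so that step bears on the present case only as a sign of how widely this position can move the number. The direction is therefore uncertain, and a further downward step seems at least as likely as a recovery, so the estimate for compound 3 is placed somewhat under compound 2 with a wide range. Compound 3 is expected at 6 ug/mL, between 1 ug/mL and 40 ug/mL, that is a step of a 2.8-fold lower number from compound 2 to compound 3 (0.45 log units; beyond the scatter).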

Compound 3, solubility: 8 ug/mL
For compound 3 the middle estimate is 1.3-fold (0.12 log units) below the measured one; low and high end bracket the measured number.
By their numbers in this assay, from the lowest: compound 3; then compound 2; then compound 1.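

In this assay, a third group at this aromatic carbon extends the range downward, and exchanging 4-aminopiperidin-1-yl for (3-carbamoylphenyl)amino gives only a modest move (a 2.1-fold lower number from compound 2 to compound 3 (0.33 log units; beyond the scatter)). The same group in place of 3-(dimethylamino)propoxy gives a much larger one (a 22-fold lower number from compound 1 to compound 3 (1.34 log units; beyond the scatter)), so among these three compounds, the large separation remains between compound 1 and the two compounds with a ring-bearing amine at this position, while replacing the non-aromatic ring with an aromatic ring of carbon only shifts the number much less. Nothing available accounts for either step.

The compounds shown leave open whether the lower number of compound 3 follows from the phenyl ring itself or from its carboxamide, a question that a plain phenylamino group or a carboxylic acid in place of the carboxamide would address. They also leave open whether the higher number of compound 1 depends on the oxygen link or on the terminal dimethylamine, which a dimethylamino chain joined through nitrogen, or a longer chain, would help separate.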